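The source may hold more compounds than are shown below. What is called first, only, known or untested is meant among the compounds shown, and "the series" means these compounds.

Measured in an assay on a protein complex for binding affinity to Neuronal acetylcholine receptor; alpha4/beta2 (Rattus norvegicus); a lower number here means a stronger inhibitor, a higher number a weaker inhibitor:
compound 1 `C#Cc1cncc(O[C@@H]2CCNC2)c1` gives 62 nM
compound 2 `Cc1cc(O[C@@H]2CCNC2)cnc1Cl` gives 64 nM
compound 3 `c1ccc(-c2cncc(O[C@@H]3CCNC3)c2)cc1` gives 1820 nM

Compound 2 holds the second highest of the three numbers; its value and that of compound 1 lie within the scatter of each other, while compound 3 sits beyond the scatter at a much higher number. Compound 4 `Clc1ncc(O[C@@H]2CCNC2)cc1-c1ccncc1` differs from compound 2 by pyridin-4-yl in place of methyl on an aromatic carbon, the entering ring ortho to a chloro group and two atoms from the ring nitrogen. For the measured compounds named here, the only measured step that bears on adding a six-membered aromatic ring to the shared core is a 29-fold higher number from compound 1 to compound 3 (1.47 log units; beyond the scatter), a large rise. A rise is therefore expected in this assay as well, estimated as a 9.4-fold higher number from compound 2 to compound 4 (0.97 log units; beyond the scatter), with some allowance. The entering ring differs from the phenyl of compound 3 and stands on another carbon of the core, so the range is kept wide. Compound 4 is estimated at 600 nM, range 150 nM to 3000 nM.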

Compound 4, half-maximal inhibitory concentration: 65 nM
For compound 4 the middle estimate is 9.2-fold (0.97 log units) above the measured one; measured number outside the range, below it.
By their numbers in this assay, from the lowest: compounds 1, 2 and 4 (each within the scatter of the next); then compound 3.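

In this assay, pyridin-4-yl in place of methyl on this aromatic carbon, ortho to a chloro group, gives a 1.0-fold higher number from compound 2 to compound 4 (0.01 log units; within the scatter), so the two groups cannot be told apart here. The large rise seen on the other carbon, a 29-fold higher number from compound 1 to compound 3 (1.47 log units; beyond the scatter), therefore does not extend to every six-membered aromatic ring on the shared core. Nothing at hand accounts for this difference between the two steps.

From the compounds shown here alone, whether phenyl on this carbon would match pyridin-4-yl remains open. So does the outcome for an amine, a carboxylic acid or a longer chain there, with or without the chloro group.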